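Halogen swap on the anilino ring of the acrylamide series

The source may report more compounds than this note shows. Statements on the series, on what has been measured and on what is new or still open speak of the compounds shown alone.

For the measured compounds named here, compound 2 `C=CC(=O)Nc1cccc(NC(=O)CSc2nc(Nc3cccc(F)c3)c3ccccc3n2)c1` is the lower of the two numbers measured so far in a functional assay on MGC-803 cells (Homo sapiens) for inhibition, read by MTT assay, with a stated time of 72 h; on this read-out lower numbers stand for stronger inhibition and higher numbers for weaker inhibition; there compound 2 gives 6250 nM. Going by the values given here, its only neighbour, compound 1 `C=CC(=O)Nc1cccc(NC(=O)CSc2nc(Nc3ccccc3Cl)c3ccccc3n2)c1`, gives 20700 nM in this assay, and the step of a 3.3-fold lower number from compound 1 to compound 2 (0.52 log units; beyond the scatter) came with 3-fluorophenyl in place of 2-chlorophenyl on the nitrogen attached to the shared core. Compound 3 `C=CC(=O)Nc1cccc(NC(=O)CSc2nc(Nc3cccc(Br)c3)c3ccccc3n2)c1` is not yet measured. It differs from compound 2 as follows: bromo in place of fluoro on an aromatic carbon, on an aromatic carbon of a six-membered aromatic ring of carbon only, meta to a large group. Among the compounds with values here, no measured step exchanges one halogen for another at the same aromatic carbon; the one measured step alters both the halogen and its position at once, so it bears only loosely on this change. On that basis no step beyond the scatter is expected in this assay, and the expected step from compound 2 to compound 3 is a 1.4-fold lower number from compound 2 to compound 3 (0.14 log units; within the scatter). Compound 3 is therefore estimated at 4500 nM, within a range from 1500 nM to 14000 nM.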

Compound 3, half-maximal inhibitory concentration: 11900 nM
For compound 3 the middle estimate is 2.6-fold (0.42 log units) below the measured one; the measured number falls inside the stated range.
By their numbers in this assay, from the lowest: compounds 2, 3 and 1 (each within the scatter of the next, the first and the last beyond it).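

Bromo in place of fluoro is the first exchange of one halogen for another at this aromatic carbon, meta to a large group, and in this assay it gives a 1.9-fold higher number from compound 2 to compound 3 (0.28 log units; within the scatter); this read-out therefore does not separate these two halogens here. The 3-bromophenyl group in place of 2-chlorophenyl gives a 1.7-fold lower number from compound 1 to compound 3 (0.24 log units; within the scatter), whereas the 3-fluorophenyl group in the same exchange gave a 3.3-fold lower number from compound 1 to compound 2 (0.52 log units; beyond the scatter), so compound 3 goes against any general claim that both of these 3-halophenyl groups stand clear of the 2-chlorophenyl group. No available data bear on the reason for these steps.

The compounds shown leave open whether a chloro group, or a non-halogen such as a methoxy group, an amine or a carboxylic acid, at this same aromatic carbon would stay within the scatter of compound 2 and compound 3 or move the number beyond it. They also leave open whether the small step between fluoro and bromo holds on any read-out other than this assay, since all three compounds are compared on this one alone.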